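From methoxymethyl to oxan-4-yl: an exposure estimate

The compounds below may be only part of what the source reports. "The series", "measured", "known", "first", "only" and "open" are said of these compounds alone.

Measured in an ADME assay on the whole organism for pharmacokinetics, with Rattus norvegicus as the target, at a dose of 5 mg/kg by the oral route (on this read-out higher numbers stand for higher exposure at the dose given and lower numbers for lower exposure), as follows:
- Compound 1 `CC(C)(O)c1ccc(-c2cnc3c(n2)N(CCC2CCOCC2)C(=O)CN3)cn1` gives 5560 ng.h/mL here
- Compound 2 `COCCN1C(=O)CNc2ncc(-c3ccc(C(C)(C)O)nc3)nc21` gives 9960 ng.h/mL here
- Compound 3 `CC(C)(O)c1ccc(-c2cnc3c(n2)N(CC2CCCCC2)CC(=O)N3)cn1` stands as "not determined" (no result reported) here, with no reported result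

Compound 1 and compound 2 lie within the usual scatter of each other, so compound 2 does not stand apart, and compound 3 adds no number. Compound 4 `CC(C)(O)c1ccc(-c2cnc3c(n2)N(CC2CCOCC2)C(=O)CN3)cn1` is unmeasured. It differs from compound 2 by oxan-4-yl in place of methoxymethyl on a saturated chain carbon bound to an amide-type nitrogen in a ring in one place. For the measured compounds named here, the one measured step that bears on this is a 1.8-fold higher number from compound 1 to compound 2 (0.25 log units; within the scatter), a closely related swap running the opposite way. Read backwards, it points to a lower number, but only within the scatter. The expected step is a 1.7-fold lower number from compound 2 to compound 4 (0.22 log units; within the scatter) and no larger change is foreseen. For compound 4 the estimate is 6000 ng.h/mL with an expected range from 2500 ng.h/mL to 14000 ng.h/mL in this read-out.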

Compound 4, area under the concentration-time curve: 3800 ng.h/mL
The estimate for compound 4 lay 1.6-fold (0.20 log units) above the measured number, and the stated range covers the measured number.
By their numbers in this assay, from the lowest: compounds 4, 1 and 2 (each within the scatter of the next, the first and the last beyond it).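

For the compounds shown here, replacing methoxymethyl with oxan-4-yl on the saturated chain carbon bound to an amide-type nitrogen in a ring gives a 2.6-fold lower number from compound 2 to compound 4 (0.42 log units; beyond the scatter), the first step beyond the scatter, although only a modest one. Replacing (oxan-4-yl)methyl with oxan-4-yl gives a 1.5-fold lower number from compound 1 to compound 4 (0.17 log units; within the scatter), so this change does not separate those two compounds. No measurement shown explains why exposure differs between these compounds.

Going by these compounds, how an amine, a carboxylic acid or a longer ether chain at this position would compare with compound 2 remains open.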